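The source may hold more compounds than are shown below. What is called first, only, known or untested is meant among the compounds shown, and "the series" means these compounds.

Of the compounds shown here, three from a small series have been measured so far. Compound 1 `COCCNC(=C\C(=O)/C=C/c1ccc(O)cc1)/C=C/c1ccc(O)cc1` gives in an ADME assay on CHO-K1 cells (Cricetulus griseus) for activation, read by fluorescence, tested at 10 uM (a lower number here means a stronger effect, a higher number a weaker effect of the compound at the concentration tested), a value of 75.1%. Compound 3 `COCCCNC(=C\C(=O)/C=C/c1ccc(O)cc1)/C=C/c1ccc(O)cc1` differs from compound 1 in a single place, (methoxymethyl in place of methoxy on a saturated chain carbon, two bonds along the chain from an amine nitrogen). In this assay compound 3 gives 97%, which makes the step of a number 21.9 percentage points higher from compound 1 to compound 3 (beyond the scatter). Compound 2 `COCCNC(=C\C(=O)/C=C/c1ccc(O)c(OC)c1)/C=C/c1ccc(O)c(OC)c1` carries a different core; how it differs from the core of compound 1 is not broken down here. In this assay compound 2 gives 84.4%. The values of compound 1 and compound 2 lie within the usual scatter of each other, so nothing can be said about their order, while the gap between compound 2 and compound 3 lies beyond that scatter.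

Compound 4 `COCCCNC(=C\C(=O)/C=C/c1ccc(O)c(OC)c1)/C=C/c1ccc(O)c(OC)c1` has not yet been measured. It relates to compound 2 exactly as compound 3 relates to compound 1: methoxymethyl in place of methoxy on a saturated chain carbon, two bonds along the chain from an amine nitrogen. Since the place is the same, this is the same change made on the other core. Going by the values given here, the only guide to its effect is the step of a number 21.9 percentage points higher from compound 1 to compound 3 (beyond the scatter), which raised the number by a modest amount, and that is the basis for expecting a rise of similar size here. The rise may come out somewhat smaller here. For compound 4 the expected step is a number 15.6 percentage points higher from compound 2 to compound 4 (beyond the scatter). For compound 4 the estimated value in this assay is therefore 100%, expected to fall between 88% and 112%.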

Compound 4, a percentage reported as activity, at one concentration (the size of the read-out at that concentration, not a potency): 81.2%
The estimate for compound 4 lay 18.8 percentage points above the measured number; the whole stated range lies above it.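

On the other core, the same lengthening of the chain, from 2-methoxyethyl to 3-methoxypropyl on the amine nitrogen, gives in this assay a number 3.2 percentage points lower from compound 2 to compound 4 (within the scatter), so on this core the change has no readable effect. Set beside the step on the core of compound 1, the result shows that the effect of this change did not carry over from one core to the other: the same change on two cores in this assay, a number 21.9 percentage points higher (beyond the scatter) from compound 1 to compound 3 and a number 3.2 percentage points lower (within the scatter) from compound 2 to compound 4, 25.1 percentage points apart, beyond the scatter of two such steps

The step seen on one core is therefore a poor guide to the step on the other, but these two pairs do not show why the cores behave differently, and with one pair on each core they give no rule for any further core.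

The compounds shown carry only a 2-methoxyethyl or a 3-methoxypropyl chain, so it remains open how a longer chain, or a chain ending in a hydroxyl, an amine or a carboxylic acid instead of a methoxy group, would behave on either core. Also open, as far as these compounds go, is whether a third core, for instance one with a fluorine in place of the hydroxyl groups, would follow compound 3 or compound 4.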